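This account rests on a few compounds, and the source may have more. Where it says the series, first, only, none or still open, it means among the compounds named here.

Compound 1 `COc1ccc(C2=NOC(c3ccc(C)cc3)C2S(=O)(=O)CC2=NCCO2)cc1`: 70.9%
Compound 2 `COc1ccc(C2=NOC(c3ccc(C)cc3)C2S(=O)(=O)CC2=NCCS2)cc1`: 52.6%
Compound 3 `O=S(=O)(CC1=NCCS1)C1=NNCC1c1ccc(Cl)cc1`: "not active" (no number reported)

All three compounds were tested in a functional assay, tested at 100 ug/mL; on this read-out higher numbers stand for a stronger effect at the one concentration tested and lower numbers for a weaker effect. Compounds 1 and 2 share one core and differ at a single spot: a group of 5 heavy atoms (3 carbon, 1 nitrogen, 1 oxygen; one five-membered non-aromatic ring with 2 hetero atoms) in place of a group of 5 heavy atoms (3 carbon, 1 nitrogen, 1 sulfur; one five-membered non-aromatic ring with 2 hetero atoms), on a saturated chain carbon bound to a sulfonyl sulfur. That change gives a number 18.3 percentage points higher from compound 2 to compound 1 (beyond the scatter). Compound 3 is built on a different core; the difference between the two cores is not broken down here. In this assay compound 3 gives "not active" (no number reported), so no number stands for it.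

Compound 4 `O=S(=O)(CC1=NCCO1)C1=NNCC1c1ccc(Cl)cc1` has not yet been measured. Among the measured compounds shown here, it comes from compound 3 by the same change as the one between compounds 2 and 1: a group of 5 heavy atoms (3 carbon, 1 nitrogen, 1 oxygen; one five-membered non-aromatic ring with 2 hetero atoms) in place of a group of 5 heavy atoms (3 carbon, 1 nitrogen, 1 sulfur; one five-membered non-aromatic ring with 2 hetero atoms), on a saturated chain carbon bound to a sulfonyl sulfur. The step from compound 3 to compound 4 in this assay is expected to be of roughly the same modest size as the earlier one, because the same change gave a number 18.3 percentage points higher from compound 2 to compound 1 (beyond the scatter) on the other core. Since the starting point in compound 3 is below any reported number, a modest rise would still leave a weak effect, with a real chance that only a limit is reported again. Compound 4 is expected to give 15% in this assay, with a range from 0% to 40%.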

Compound 4, a percentage reported as activity, at one concentration (the size of the read-out at that concentration, not a potency): "not active" (no number reported)
Nothing numeric was reported for compound 4; the estimate stays without a comparison.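

In this assay compound 3 gives "not active" (no number reported) and compound 4 gives "not active" (no number reported), so no step can be read between them. Going by these compounds, whether the same ring change, which gave a number 18.3 percentage points higher from compound 2 to compound 1 (beyond the scatter), has any effect on the core of compound 3 stays open. No supporting data bear on this result.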